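Hydroxyphenyl for bromophenyl at the hydrazone of compound 3

The compounds below may be only part of what the source reports. "The series", "measured", "known", "first", "only" and "open" are said of these compounds alone.

Measured so far:
- compound 1, `Fc1ccc(CSc2nnc(-c3ccncc3)n2-c2ccccc2)cc1`: 12800 nM
- compound 2, `c1ccc(CSc2nnc(-c3ccncc3)n2-c2ccccc2)cc1`: 16900 nM
- compound 3, `O=C(CSc1nnc(-c2ccncc2)n1-c1ccccc1)N/N=C/c1ccc(Br)cc1`: 4500 nM

All three share one core and were tested in a functional assay on HCT-116 cells (Homo sapiens) for inhibition, read by MTT assay, with a stated time of 48 h; on this read-out lower numbers stand for stronger inhibition and higher numbers for weaker inhibition. Compound 1 gives 12800 nM and compound 2 gives 16900 nM; the step between them is a 1.3-fold higher number from compound 1 to compound 2 (0.12 log units; within the scatter), so these two cannot be told apart. Compound 3 gives 4500 nM and stands lowest of the three numbers, beyond the scatter from both compound 1 and compound 2.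

Compound 4, `O=C(CSc1nnc(-c2ccncc2)n1-c1ccccc1)N/N=C/c1ccccc1O`, has not yet been measured. It differs from compound 3 in one place: 2-hydroxyphenyl in place of 4-bromophenyl on a carbon with a double bond to nitrogen. For the measured compounds named here, the only measured step, from compound 1 to compound 2, touches a different part of the molecule and is within the scatter, so no measured step bears directly on this change. Going by the values given here, what is known is only that the hydrazone-bearing compound 3 gives the lowest number among the three. In this assay compound 4 is therefore expected to land near compound 3, with a step of a 1.3-fold higher number from compound 3 to compound 4 (0.12 log units; within the scatter), which is not expected to exceed the scatter by much in either direction. The estimate for compound 4 is 6000 nM, with a range from 2500 nM to 15000 nM.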

Compound 4, half-maximal inhibitory concentration: 7060 nM
Compound 4: the middle estimate sits 1.2-fold (0.07 log units) below what was measured; the range from low to high includes it.
By their numbers in this assay, from the lowest: compounds 3, 4, 1 and 2 (each within the scatter of the next, the first and the last beyond it).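

For the compounds shown here, this is the first change measured at the far end of the hydrazone: in this assay, putting 2-hydroxyphenyl in place of 4-bromophenyl on a carbon with a double bond to nitrogen gives a step (a 1.6-fold higher number from compound 3 to compound 4 (0.20 log units; within the scatter)) too small to separate the two compounds. The earlier compounds shown here included only one with this hydrazone, so they could not show that this position accepts a second aromatic group with no measurable change, even though bromine leaves and a hydrogen-bond donor and acceptor enter. No measurement here explains this result.

As far as these compounds go, the swap alters both the substituent and its place on the ring, so the effect of each alone remains unknown, and it is also open whether an amine, a carboxylic acid or a longer alkyl chain at this position would keep the number in the same range. Compounds 3 and 4 also differ from compounds 1 and 2 in more than one place, so which part of the hydrazone side chain matters in this assay remains unresolved.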